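This account rests on a few compounds, and the source may have more. Where it says the series, first, only, none or still open, it means among the compounds named here.

Compound 1 `OC1C[C@@H]2CCCC[C@@H]2[C@H]1/C=C/c1ccc(-c2cccc(F)c2)cn1` gives 220 nM in an assay on cell membranes for displacement of a labelled ligand from proteinase-activated receptor 1 (Homo sapiens), read by scintillation counting, with a stated time of 60 min (on this read-out lower numbers stand for stronger inhibition and higher numbers for weaker inhibition), which places it second highest among the three measured numbers, with compound 3 closest and compound 2 furthest from it. Compound 2 `COC1C[C@@H]2CCCC[C@@H]2[C@H]1/C=C/c1ccc(-c2cccc(F)c2)cn1` gives 67 nM in this assay, and the change from compound 1 to compound 2 brought a 3.3-fold lower number from compound 1 to compound 2 (0.52 log units; beyond the scatter). Compound 3 `Fc1cccc(-c2ccc(/C=C/[C@H]3C(OCc4ccccc4)C[C@@H]4CCCC[C@@H]43)nc2)c1` gives 280 nM, and the change from compound 1 to compound 3 brought a 1.3-fold higher number from compound 1 to compound 3 (0.10 log units; within the scatter). Compound 4 `CS(=O)(=O)OC1C[C@@H]2CCCC[C@@H]2[C@H]1/C=C/c1ccc(-c2cccc(F)c2)cn1` has not been measured; it differs from compound 1 by methylsulfonyl in place of hydrogen on an oxygen on a saturated carbon. Both measured steps replace the same hydrogen on that oxygen: methyl gave a modest gain, benzyl gave no step beyond the scatter. Neither group is a methylsulfonyl, so the outcome for compound 4 is uncertain, and a step of modest size in either direction, or none beyond the scatter, is plausible. Compound 4 is therefore expected to give about 180 nM in this assay, within roughly 60 nM to 550 nM, meaning an expected step of a 1.2-fold lower number from compound 1 to compound 4 (0.09 log units; within the scatter).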

Compound 4, half-maximal inhibitory concentration: 6.4 nM
Compound 4: the middle estimate sits 28-fold (1.45 log units) above what was measured; the measured number lies below the stated range.
By their numbers in this assay, from the lowest: compound 4; then compound 2; then compounds 1 and 3 (each within the scatter of the next).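

For the compounds shown here, the oxygen on this saturated carbon proves far more sensitive to what is attached than the earlier compounds showed: methylsulfonyl in place of hydrogen brings a 34-fold lower number from compound 1 to compound 4 (1.54 log units; beyond the scatter), whereas methyl and benzyl on the same oxygen had given a modest step or none beyond the scatter. The new group also stands well clear of both earlier replacements, with a 10-fold lower number from compound 2 to compound 4 (1.02 log units; beyond the scatter) for methylsulfonyl in place of methyl and a 44-fold lower number from compound 3 to compound 4 (1.64 log units; beyond the scatter) for methylsulfonyl in place of benzyl. Removing the hydrogen is therefore not enough in itself to reach this level, as compound 2 and compound 3 lack it too.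

Nothing measured here explains why methylsulfonyl stands apart. From the compounds shown here alone, whether other groups on this oxygen, such as acetyl or phenylsulfonyl, would match it remains open, as does the effect of an amine in place of the oxygen.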